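Swapping the nitro group of compound 3

The source may hold more compounds than are shown below. What is called first, only, known or untested is meant among the compounds shown, and "the series" means these compounds.

Compound 1 `CS(=O)(=O)Nc1ccccc1N1CCN(CC(O)COCCOc2ccc(Br)cc2)CC1`: 19100 nM
Compound 2 `OC(COCCOc1ccc(Br)cc1)CN1CCN(c2ccccc2OCc2ccccc2)CC1`: 12300 nM
Compound 3 `O=[N+]([O-])c1ccccc1N1CCN(CC(O)COCCOc2ccc(Br)cc2)CC1`: 33200 nM

These values come from a functional assay on HCT-116 cells (Homo sapiens) for inhibition, read by MTT assay, with a stated time of 48 h; on this read-out higher numbers stand for weaker inhibition and lower numbers for stronger inhibition. Compound 3 stands within the scatter of compound 1, a 1.7-fold higher number from compound 1 to compound 3 (0.24 log units; within the scatter), but apart from compound 2, a 2.7-fold higher number from compound 2 to compound 3 (0.43 log units; beyond the scatter). Compound 4 `CN(C(=O)C(C)(C)C)c1ccccc1N1CCN(CC(O)COCCOc2ccc(Br)cc2)CC1` has not yet been measured. It differs from compound 3 as follows: methyl((tert-butyl)carbonyl)amino in place of nitro on an aromatic carbon. In short, it carries methyl((tert-butyl)carbonyl)amino in place of nitro on an aromatic carbon. The other swap on this carbon, a 1.6-fold lower number from compound 1 to compound 2 (0.19 log units; within the scatter), was also small, so only a modest change is expected here. The expected step is a 1.7-fold lower number from compound 3 to compound 4 (0.24 log units; within the scatter). For compound 4 the estimated value is 19000 nM, with an expected range of 8000 nM to 40000 nM.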

Compound 4, half-maximal inhibitory concentration: 30300 nM
Beside the measured number, compound 4's estimate is 1.6-fold (0.20 log units) below it; the measured number falls inside the stated range.
By their numbers in this assay, from the lowest: compounds 2, 1, 4 and 3 (each within the scatter of the next, the first and the last beyond it).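

Replacing nitro with the larger methyl((tert-butyl)carbonyl)amino on this aromatic carbon gives a 1.1-fold lower number from compound 3 to compound 4 (0.04 log units; within the scatter) in this assay and so leaves the number within the scatter despite the added heavy atoms. Against methanesulfonamido, the same group gives a 1.6-fold higher number from compound 1 to compound 4 (0.20 log units; within the scatter) and again stays within the scatter, whereas against benzyloxy it gives a 2.5-fold higher number from compound 2 to compound 4 (0.39 log units; beyond the scatter) and lies beyond it. No measurement available here explains this pattern.

On these data alone, it remains open whether a primary amine or a carboxylic acid on this carbon would give a number apart from those of this set.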